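Extending the Sugar Hydroxyl with a Triol Branch

The source may report more compounds than this note shows. Statements on the series, on what has been measured and on what is new or still open speak of the compounds shown alone.

Among the compounds with values here, compound 2, `CCCCCCCC/C=C\CCCCCCCC(=O)N[C@H]1[C@@H](OCCCCCCCC)O[C@H](CO)[C@@H](O)[C@@H]1O`, is the one compound here with a measured number: in a functional assay on C6 cells (Rattus norvegicus), read by thymidine incorporation (a higher number here means a weaker inhibitor, a lower number a stronger inhibitor), compound 2 gives 12 uM. Two related compounds stand beside it. Compound 1, `CC(=O)N[C@H]1[C@@H](OCCCCc2ccccc2)O[C@H](CO)[C@@H](O)[C@@H]1O`, reaches in this assay only a limit, not a number: compound 1 gives > 50 uM. That entry is the limit of > 50 uM in this assay, at which 1 of the 3 values shown sits. Compound 3, `CCCCCCCCCCCCCCCCO[C@H]1O[C@H](COCC(O)CO)[C@@H](O)[C@H](O)[C@H]1NC(=O)CCCC`, has no single number in this assay: for compound 3 the entry reads "not determined" (no result reported). Within the data shown here, no two measured compounds differ in a single place, so no measured step can be read off. Compound 4, `CCCCCCCC/C=C\CCCCCCCC(=O)N[C@H]1[C@@H](OCCCCCCCC)O[C@H](COCC(CO)(CO)CO)[C@@H](O)[C@@H]1O`, is yet to be measured; it differs from compound 2 in one place: 3-hydroxy-2,2-bis(hydroxymethyl)propyl in place of hydrogen on an oxygen on a saturated carbon. Among the measured compounds shown here, with no measured step of this kind to lean on, the expectation rests on compound 2 alone, and the added branch is expected to move the value only modestly, if at all, with the expected step being a 1.7-fold higher number from compound 2 to compound 4 (0.22 log units; within the scatter), a shift that need not exceed the usual scatter. Compound 4 is therefore estimated at 20 uM, within a range from 6 uM to 60 uM.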

Compound 4, concentration for 50% inhibition: 11.9 uM
Estimate against measurement, compound 4: 1.7-fold (0.23 log units) above, and the stated range covers the measured number.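

In this assay, within the data shown here, this gives the set its only measured step: a 1.0-fold lower number from compound 2 to compound 4 (0.00 log units; within the scatter). It shows that the hydroxymethyl group of compound 2 can carry 3-hydroxy-2,2-bis(hydroxymethyl)propyl on its oxygen, a branch of 8 heavy atoms with 3 hydrogen-bond donors, and that the two compounds still read alike in this assay. Nothing shown here explains why they read alike.

What the compounds shown leave open is whether this oxygen accepts other kinds of group equally well, such as a chain ending in an amine or a carboxylic acid, or a longer chain carrying the same hydroxyl groups. On these data alone, it also remains open whether the same branch would read alike on the core of compound 1 or compound 3.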